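This account rests on a few compounds, and the source may have more. Where it says the series, first, only, none or still open, it means among the compounds named here.

Compound 3 `CCCCc1ccccc1C(SCCC(=O)O)SCCC(=O)O` gives no number in an assay on membranes from lung (Cavia porcellus) for binding affinity to cysteinyl leukotriene receptor (Homo sapiens); on this read-out higher numbers stand for weaker inhibition and lower numbers for stronger inhibition: for compound 3 the assay reports only a limit, > 20000 nM. Its two longer-chained analogues are measured. Compound 1 `CCCCCCCCCCCCc1ccccc1C(SCCC(=O)O)SCCC(=O)O` gives 445 nM in this assay, and compound 2 `CCCCCCCCCCc1ccccc1C(SCCC(=O)O)SCCC(=O)O` gives 1180 nM. The steps from those compounds to compound 3 are large, an at least 44-fold higher number from compound 1 to compound 3 (1.65 log units; beyond the scatter) and an at least 16-fold higher number from compound 2 to compound 3 (1.22 log units; beyond the scatter), while the shortening between the two measured chains is modest, a 2.7-fold higher number from compound 1 to compound 2 (0.42 log units; beyond the scatter). Compound 4 `CCCCc1ccc(CCCCc2ccccc2C(SCCC(=O)O)SCCC(=O)O)cc1` runs these steps in the opposite direction: 4-butylphenyl in place of hydrogen on a saturated chain carbon, four bonds along the chain from an aromatic carbon. The entering group is of similar length to the octyl of compound 1, though it carries an aromatic ring rather than a saturated chain. Because the removal steps were at least as large as an at least 16-fold higher number from compound 2 to compound 3 (1.22 log units; beyond the scatter), the writer expects a large gain from re-filling this position. The step is expected to be an at least 33-fold lower number from compound 3 to compound 4 (1.52 log units; beyond the scatter). Since compound 3 sits at the limit (the limit of > 20000 nM in this assay, at which 1 of the 3 values shown sits), the true size of the gain is uncertain. Compound 4 is expected to come out near 600 nM, between 150 nM and 3000 nM.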

Compound 4, inhibition constant: 4230 nM
Compound 4: middle estimate off by 7.1-fold (0.85 log units), on the low side; the measured number lies above the stated range.
By their numbers in this assay, from the lowest: compound 1; then compound 2; then compound 4. At a limit, above all of these: compound 3.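

In this assay, 4-butylphenyl on this saturated chain carbon brings the series back to a measured number, an at least 4.7-fold lower number from compound 3 to compound 4 (0.67 log units; beyond the scatter), and that gain can be read only as a minimum because compound 3 stands at a limit: the limit of > 20000 nM in this assay, at which 1 of the 4 values shown sits. The same group does not match the saturated chains at this place, with a 3.6-fold higher number from compound 2 to compound 4 (0.55 log units; beyond the scatter) and a 9.5-fold higher number from compound 1 to compound 4 (0.98 log units; beyond the scatter). Length alone therefore does not set the number here, since the entering group, of similar length to the octyl of compound 1, carries an aromatic ring and falls short of it.

The compounds shown leave open whether a plain phenyl, without the butyl, or a chain longer than the octyl would do better at this place. They also leave open what an ether oxygen within the chain, or an amine at its end, would do.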